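Working notes: compound 2 to compound 3

The source may hold more compounds than are shown below. What is called first, only, known or untested is meant among the compounds shown, and "the series" means these compounds.

Measured so far in an ADME assay on HEK293 cells (Homo sapiens) for cytotoxicity, read by MTT assay, with a stated time of 24 h; a higher number here means a weaker inhibitor, a lower number a stronger inhibitor
- compound 1 `COC(=O)c1scc(-c2ccc(NC(=O)c3ccc(C(F)(F)F)cc3Br)cc2)c1OC` gives > 50000 nM (a limit of the assay, not a number)
- compound 2 `COC(=O)c1scc(-c2ccc(NC(=O)c3cc(I)ccc3F)cc2)c1OC` gives 45300 nM

Among the compounds with values here, compound 2 at 45300 nM holds the only true number so far. Compound 1 gives only the limit > 50000 nM and no number. Within the data shown here, no two measured compounds differ in one place, so the series offers no measured step to lean on.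

Compound 3 `COC(=O)c1scc(-c2ccc(NC(=O)c3ccc(C(F)(F)F)cc3)cc2)c1OC` carries 4-(trifluoromethyl)phenyl in place of 2-fluoro-5-iodophenyl on a carbonyl carbon and otherwise matches compound 2. The estimated move a 1.1-fold higher number from compound 2 to compound 3 (0.03 log units; within the scatter) is expected to stay within the scatter, with no direction favoured. That expectation rests on compound 2 at 45300 nM. It also rests on compound 1, which gives the limit > 50000 nM. In this assay compound 3 is expected at 48000 nM with an estimated range from 25000 nM to 90000 nM for now.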

Compound 3, half-maximal inhibitory concentration: 48300 nM
Estimate against measurement, compound 3: 1.0-fold (0.00 log units) below, within the range that was stated.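

In this assay, 4-(trifluoromethyl)phenyl in place of 2-fluoro-5-iodophenyl on a carbonyl carbon gives a 1.1-fold higher number from compound 2 to compound 3 (0.03 log units; within the scatter), so exchanging the whole aryl group at this position does not separate the two compounds beyond the scatter. Hydrogen in place of bromo on an aromatic carbon gives an at least 1.0-fold lower number from compound 1 to compound 3 (0.01 log units; that floor lies within the scatter), which is only a floor, so no size or direction can be read for the bromo group. Compound 1 holds a limit of the assay and not a number: the limit of > 50000 nM in this assay, at which 1 of the 3 values shown sits.

No step shown moves the number beyond the scatter, so it remains open whether any change at this position can do so. Going by these compounds, it also remains open how this assay responds to an aliphatic amine or a carboxylic acid on the phenyl ring in place of these halogen-bearing groups.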